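Working notes: methyl on compound 3

The source may report more compounds than this note shows. Statements on the series, on what has been measured and on what is new or still open speak of the compounds shown alone.

In a functional assay on HT-29 cells (Homo sapiens) for antiproliferative activity, with a stated time of 4 h (on this read-out higher numbers stand for weaker inhibition and lower numbers for stronger inhibition), compound 1 (`O=C1CCc2c1c1c(c3c2[nH]c2ccccc23)C(=O)NC1=O`) gives 16100 nM and compound 2 (`O=C1NC(=O)c2c1c1c(O)cccc1c1[nH]c3ccccc3c21`) gives 46400 nM while compound 3 (`O=C1NC(=O)c2c1c1c(O)ccc(O)c1c1[nH]c3ccccc3c21`) gives 5600 nM as the lowest of the three numbers, beyond the scatter from both others.

Compound 4 (`Cc1ccc2[nH]c3c4c(O)ccc(O)c4c4c(c3c2c1)C(=O)NC4=O`) differs from compound 3 by methyl in place of hydrogen on an aromatic carbon and has not yet been measured. Going by the values given here, the one measured step, an 8.3-fold lower number from compound 2 to compound 3 (0.92 log units; beyond the scatter) for hydroxy in place of hydrogen on an aromatic carbon, lies beyond the scatter but involves a different group. Among the compounds with values here, no measured step involves methyl, so neither the size nor the direction of this change has a direct precedent. No shift beyond the scatter is expected, and the estimated change is a 1.1-fold lower number from compound 3 to compound 4 (0.05 log units; within the scatter) on this reading of the series. In this assay compound 4 is estimated at 5000 nM (expected range 1800 nM to 15000 nM).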

Compound 4, half-maximal inhibitory concentration: 3800 nM
Estimate against measurement, compound 4: 1.3-fold (0.12 log units) above; the range from low to high includes it.
By their numbers in this assay, from the lowest: compounds 4 and 3 (each within the scatter of the next); then compound 1; then compound 2.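

In this assay, methyl in place of hydrogen on an aromatic carbon, at the position meta to a fused ring and para to a fused ring, gives a 1.5-fold lower number from compound 3 to compound 4 (0.17 log units; within the scatter). Going by these compounds alone, this is the first reading at this position and the first for methyl: on compound 3, the added carbon leaves the number within the scatter, whereas the only earlier step, an 8.3-fold lower number from compound 2 to compound 3 (0.92 log units; beyond the scatter), lies beyond it for hydroxy in place of hydrogen. No measurement bears on why methyl is accommodated here without a shift beyond the scatter.

The compounds shown leave open whether a longer chain, an amine or a carboxylic acid on this carbon would move the number beyond the scatter. They also leave open whether methyl at this position would read the same on compound 2.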